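The source may hold more compounds than are shown below. What is called first, only, known or untested is meant among the compounds shown, and "the series" means these compounds.

Working notes on the series, read in an in vitro ADME assay on microsomes from liver (Rattus norvegicus) for metabolic stability; a lower number here means slower removal, a higher number faster removal of the compound. Going by the values given here, compound 2 (`Clc1cccc(-c2ccc(N3CCCCC3)nn2)c1Cl`) gives 35 mL.min-1.g-1, the highest of the three numbers so far. Compound 1 (`C[C@@H]1CC[C@H](C)N1c1ccc(-c2cncc3ccccc23)nn1`) gives 3.7 mL.min-1.g-1 and compound 3 (`C[C@@H]1CC[C@H](C)N1c1ccc(-c2cccc3cnccc23)nn1`) gives 5.1 mL.min-1.g-1. Both of these lie beyond the scatter below compound 2, with compound 3 the nearer of the two.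

The next compound to be read is compound 4 (`C[C@@H]1CC[C@H](C)N1c1ccc(-c2cccc(Cl)c2Cl)nn1`), which departs from compound 2 at a single place: 2,5-dimethylpyrrolidin-1-yl in place of piperidin-1-yl on an aromatic carbon. In words, 2,5-dimethylpyrrolidin-1-yl stands in place of piperidin-1-yl on an aromatic carbon, and the rest of compound 2 is kept.

The entering group is already present in compound 1 at 3.7 mL.min-1.g-1 and in compound 3 at 5.1 mL.min-1.g-1, which points towards a lower number. Both compounds also differ from compound 2 elsewhere in the structure, however, so the data do not isolate this change, and only part of that gap should carry over. The expected result is a moderate drop, just beyond the scatter, stated as a 2.5-fold lower number from compound 2 to compound 4 (0.40 log units; beyond the scatter). For compound 4 the estimated value in this assay is 14 mL.min-1.g-1, with an expected range of 5 mL.min-1.g-1 to 40 mL.min-1.g-1.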

Compound 4, intrinsic clearance in microsomes: 9.7 mL.min-1.g-1
The estimate for compound 4 lay 1.4-fold (0.16 log units) above the measured number, within the range that was stated.
By their numbers in this assay, from the lowest: compounds 1, 3 and 4 (each within the scatter of the next, the first and the last beyond it); then compound 2.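

Within this assay, the series now has its first comparison confined to this position, the aromatic carbon next to the ring nitrogen: 2,5-dimethylpyrrolidin-1-yl in place of piperidin-1-yl gives a 3.6-fold lower number from compound 2 to compound 4 (0.56 log units; beyond the scatter). The earlier compounds shown here could not show this, as the group entering here appeared in them only on a different core from that of compound 2, whereas this step keeps the rest of compound 2 unchanged. The change at this one position is therefore enough on its own to carry the number beyond the scatter, although the step is modest in size and compound 4 still rests on a single comparison. No measurement here bears on why the number moves with this change.

The step combines a change from a six-membered to a five-membered ring with the addition of two defined stereocentres, so the compounds shown do not separate the contribution of ring size from that of the two methyl groups. Unsubstituted pyrrolidin-1-yl would divide the step between these, while morpholin-4-yl or an open-chain diethylamino group would test how far the position tolerates other amines.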